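The source may hold more compounds than are shown below. What is called first, only, known or untested is meant among the compounds shown, and "the series" means these compounds.

Compound 1, with the structure `COc1ccc(CN(C(=O)CCl)c2cc(OC)c(OC)c(OC)c2)cc1O`, is measured in a functional assay on MGC-803 cells (Homo sapiens) for inhibition, read by MTT assay, with a stated time of 48 h (on this read-out higher numbers stand for weaker inhibition and lower numbers for stronger inhibition), where compound 1 gives 84 nM. Among the two compounds for which a number, rather than a limit, is known, compound 1 gives the lowest, so it is the strongest inhibitor of that pair. Its companion, compound 2 with the structure `COc1ccc(CNc2cc(OC)c(OC)c(OC)c2)cc1`, carries no acyl group on the nitrogen and gives 11400 nM in this assay. Compound 3, with the structure `COc1cc(NCc2ccc(Br)cc2)cc(OC)c1OC`, reaches only the limit > 80000 nM in this assay. Among the compounds with values here, the one measured step, an at least 7.0-fold higher number from compound 2 to compound 3 (0.84 log units; beyond the scatter), concerns a substituent on an aromatic ring and is at least modest in size; it rests on (the limit of > 80000 nM in this assay, at which 1 of the 3 values shown sits).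

The compound not yet measured is compound 4, with the structure `COc1ccc(CN(C(=O)C(C)C)c2cc(OC)c(OC)c(OC)c2)cc1O`. Relative to compound 1 it differs by isopropyl in place of chloromethyl on a carbonyl carbon. Within the data shown here, no measured step touches the carbonyl carbon, so the change from compound 2 to compound 3 does not bear on it. The two values of compound 1 and compound 2 show only that removing the whole acyl group goes with a far higher number. An upward step in this assay, beyond the scatter, is therefore expected for compound 4, of about an 18-fold higher number from compound 1 to compound 4 (1.25 log units; beyond the scatter), giving an estimated value of 1500 nM, with a range from 200 nM to 15000 nM.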

Compound 4, half-maximal inhibitory concentration: 210 nM
For compound 4 the middle estimate is 7.1-fold (0.85 log units) above the measured one; measured number inside the range.
By their numbers in this assay, from the lowest: compound 1; then compound 4; then compound 2. At a limit, above all of these: compound 3.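

Within the data shown here, the carbonyl carbon had no measured step until now, and this change gives a 2.5-fold higher number from compound 1 to compound 4 (0.40 log units; beyond the scatter) in this assay. The step is real but modest, so an inhibitor with a number in the same low range as compound 1 does not depend on the chlorine of the chloromethyl group: compound 4, whose isopropyl group is made of carbon and hydrogen alone, still gives 210 nM, and the position accepts a branched group at only a small cost. The compounds shown offer no measurement that explains why isopropyl gives the somewhat higher number, so the size of the step can be stated but no cause can be given for it.

Among these compounds, with only two groups compared at this carbonyl carbon, it remains open how far the position tolerates change, for example whether a plain methyl, a longer chain such as n-butyl, an aminomethyl group or one carrying a carboxylic acid would keep the number this low. It also remains open what the acyl group contributes as a whole, since no pair shown differs only by its presence.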